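The source may report more compounds than this note shows. Statements on the series, on what has been measured and on what is new or still open speak of the compounds shown alone.

Compound 1, `COc1ccc(/C=C/C2CC(=O)C=CO2)cc1`, and compound 2, `COc1ccc(/C=C/C2CC(=O)C=CO2)cc1OC`, share one core, and in a functional assay on MCF7 cells (Homo sapiens) for inhibition, read by sulforhodamine B assay, with a stated time of 48 h (a higher number here means a weaker inhibitor of growth, a lower number a stronger inhibitor of growth), compound 1 gives 156 uM while compound 2 gives 130 uM. The change between them is methoxy in place of hydrogen on an aromatic carbon, and that step was a 1.2-fold lower number from compound 1 to compound 2 (0.08 log units; within the scatter). Compound 3, `COc1cc(/C=C/C2CC=CC(=O)O2)cc(OC)c1`, has a different core; the difference between the two cores is not broken down here. In this assay compound 3 gives 9.5 uM, the lowest number of the three and beyond the scatter from both others. Compound 4, `COc1cc(/C=C/C2CC=CC(=O)O2)cc(OC)c1OC`, differs from compound 3 by methoxy in place of hydrogen on an aromatic carbon. This is the same kind of change as before, but here the new group sits ortho to two methoxy groups and para to the group of 9 heavy atoms, rather than ortho to one methoxy group and meta to it. Because the earlier step of a 1.2-fold lower number from compound 1 to compound 2 (0.08 log units; within the scatter) stayed within the scatter, the step from compound 3 to compound 4 is expected to be a 1.2-fold lower number from compound 3 to compound 4 (0.07 log units; within the scatter). Compound 4 is therefore estimated at 8 uM in this assay, expected between 3 uM and 25 uM.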

Compound 4, concentration for growth inhibition (reported as GI): 15.3 uM
Estimate against measurement, compound 4: 1.9-fold (0.28 log units) below; measured number inside the range.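

In this assay, methoxy in place of hydrogen on an aromatic carbon gave a 1.6-fold higher number from compound 3 to compound 4 (0.21 log units; within the scatter). Set side by side, the two steps cannot be told apart: the same change on two cores in this assay, a 1.2-fold lower number (0.08 log units; within the scatter) from compound 1 to compound 2 and a 1.6-fold higher number (0.21 log units; within the scatter) from compound 3 to compound 4, 1.9-fold (0.29 log units) apart, within the scatter of two such steps. On these two cores, then, the change carries over as a step too small to read, but two pairs say nothing about other cores or other positions on the ring, and a small real shift in either direction could hide inside the scatter.

Still open, from the compounds shown here alone, is whether another group in this place, such as an amine, a carboxylic acid or a longer chain, would move the number beyond the scatter. Also open is what the difference between the cores contributes: no pair shown differs in the core alone.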